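Swapping pyridin-2-yl for 4-methylphenyl on a shared core

A few compounds are considered here, and "the series" means these few. Any claim that something is new, unique, unknown or untested is made for them only; others in the source may bear on it.

Measured in an ADME assay on HepG2 cells (Homo sapiens) for cytotoxicity, read by fluorescence and resazurin assay, with a stated time of 24 h; a lower number here means that less compound is tolerated, a higher number that more compound is tolerated
Compound 1 `O=S1(=O)C=C(Sc2nnc(-c3cccnc3)o2)c2ccccc21` gives 14000 nM
Compound 2 `Nc1ccc(-c2nnc(SC3=CS(=O)(=O)c4ccccc43)o2)cc1` gives 24000 nM
Compound 3 `O=S1(=O)C=C(Sc2nnc(-c3ccccn3)o2)c2ccccc21` gives 24000 nM

These three compounds share one core and differ only in a single aromatic group. Compound 3 stands level with one of its two neighbours, as the comparison shows no change at the digits printed from compound 2 to compound 3 (within the scatter) and it is not separated from the other one either.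

The next compound to consider is compound 4 `Cc1ccc(-c2nnc(SC3=CS(=O)(=O)c4ccccc43)o2)cc1` which carries 4-methylphenyl in place of pyridin-2-yl on an aromatic carbon. Two further measured swaps at this same place bear on the question. Replacing pyridin-3-yl with 4-aminophenyl gave a 1.7-fold higher number from compound 1 to compound 2 (0.23 log units; within the scatter) and replacing pyridin-3-yl with pyridin-2-yl gave a 1.7-fold higher number from compound 1 to compound 3 (0.23 log units; within the scatter) so no swap seen so far has moved the number beyond the scatter. None of these compounds carries 4-methylphenyl, and three compounds are a thin basis, so the expectation stays modest.

In this assay no step beyond the scatter is expected, and the estimate amounts to a 1.2-fold lower number from compound 3 to compound 4 (0.08 log units; within the scatter) as the expected step. Compound 4 is expected at 20000 nM with 9000 nM to 45000 nM as the estimated range.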

Compound 4, half-maximal cytotoxic concentration: 31000 nM
Beside the measured number, compound 4's estimate is 1.6-fold (0.19 log units) below it, within the range that was stated.
By their numbers in this assay, from the lowest: compounds 1, 2, 3 and 4 (each within the scatter of the next, the first and the last beyond it).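

In this assay, 4-methylphenyl in place of pyridin-2-yl gives a 1.3-fold higher number from compound 3 to compound 4 (0.11 log units; within the scatter), and methyl in place of amino on an aromatic carbon gives a 1.3-fold higher number from compound 2 to compound 4 (0.11 log units; within the scatter), so this ring of carbon only is not separated from either of those two neighbours. Going by these compounds alone, what the earlier compounds did not show is a step at this position that passes the scatter: 4-methylphenyl in place of pyridin-3-yl gives a 2.2-fold higher number from compound 1 to compound 4 (0.35 log units; beyond the scatter), a modest step, and this is the only pair among the four compounds separated in this way. Nothing available here accounts for that step.

Going by these compounds, all four compounds carry a six-membered aromatic ring at this place, so it remains open whether a carboxylic acid, a simple amine or a longer chain attached there would stay in the same range. On these data alone, it also remains open whether the small separation between compound 1 and compound 4 would hold up with further pyridine or methyl-bearing groups at this position, or on other versions of the shared core.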